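The compounds below may be only part of what the source reports. "The series", "measured", "known", "first", "only" and "open" are said of these compounds alone.

Measured in an ADME assay on microsomes from liver (Mus musculus) for metabolic stability; on this read-out higher numbers stand for fast clearance and lower numbers for slow clearance:
- compound 1 `Oc1c(-c2nnc(Cc3ccc(Cl)cc3)[nH]2)ncc2cccnc12`: 16 mL.min-1.g-1
- compound 2 `Oc1c(-c2nc(C(O)c3ccccc3)n[nH]2)ncc2cccnc12`: 1.9 mL.min-1.g-1

Compound 2 holds the lower of the two numbers at 1.9 mL.min-1.g-1, and compound 1 stands higher at 16 mL.min-1.g-1, a gap beyond the scatter. The two differ in more than one place, so this gap cannot be assigned to a single change.

Next in line is compound 3 `Cc1n[nH]c(-c2ncc3cccnc3c2O)n1`, with methyl in place of hydroxy(phenyl)methyl on an aromatic carbon. Among the measured compounds shown here, no measured step covers this change, so the expectation is weakly grounded and starts from compound 2 at 1.9 mL.min-1.g-1. In this assay, the expected 1.3-fold higher number from compound 2 to compound 3 (0.12 log units; within the scatter) stays within the scatter, with any drift more likely upward. For compound 3 the estimate is 2.5 mL.min-1.g-1, with an expected range of 0.8 mL.min-1.g-1 to 8 mL.min-1.g-1.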

Compound 3, intrinsic clearance in microsomes: 3.3 mL.min-1.g-1
Beside the measured number, compound 3's estimate is 1.3-fold (0.12 log units) below it; measured number inside the range.
By their numbers in this assay, from the lowest: compounds 2 and 3 (each within the scatter of the next); then compound 1.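

In this assay, the exchange of hydroxy(phenyl)methyl for methyl on the aromatic carbon of the five-membered aromatic ring gives a 1.7-fold higher number from compound 2 to compound 3 (0.24 log units; within the scatter). Among the compounds shown here, this is the first single-place step at this position, and it shows that the read-out stays within the scatter when a group of eight heavy atoms, with its six-membered aromatic ring, gives way to methyl. No supporting measurement is available to explain this outcome.

As far as these compounds go, the hydroxy and the phenyl leave together in this one step, so their separate contributions remain open. From the compounds shown here alone, it also remains open whether a hydroxymethyl, an aminomethyl, a carboxylic acid or a longer alkyl chain at this position would stay in the same range.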